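The source may hold more compounds than are shown below. What is called first, only, known or untested is meant among the compounds shown, and "the series" means these compounds.

Working notes on the series in a functional assay on SMMC-7721 cells (Homo sapiens) for antiproliferative activity, read by MTT assay, with a stated time of 48 h; on this read-out higher numbers stand for weaker inhibition and lower numbers for stronger inhibition.

Of the compounds shown here, two on the shared core carry numbers so far. Compound 1 `CO[C@]1(C)/C=C/C(=O)/C(CO)=C\C[C@](C)(CCC=C(C)C)/C=C/[C@H]1OC(=O)C=C(C)C` in this assay gives 15800 nM. Compound 2 `CC(C)=CCC[C@]1(C)/C=C/[C@@H](OC(=O)C=C(C)C)[C@](C)(O)/C=C/C(=O)/C(CN2CCCC2)=C\C1` in this assay gives 140 nM, the lowest of the two numbers; the gap to compound 1 lies far beyond the scatter of repeated measurements, so compound 2 is clearly the stronger inhibitor of the pair. Going by the values given here, no two measured compounds differ in one place only, so nothing in the measured set tells directly how a single change on this core moves the read-out.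

Compound 3 `CC(C)=CCC[C@]1(C)/C=C/[C@@H](OC(=O)C=C(C)C)[C@](C)(O)/C=C/C(=O)/C(C(=O)N2CCCC2)=C\C1` remains to be measured. Against compound 2 it differs in one place: (pyrrolidin-1-yl)carbonyl in place of (pyrrolidin-1-yl)methyl on a double-bonded ring carbon. Among the compounds with values here, with no comparable step measured, the expectation rests on the structural change alone. The expected step is a 3.2-fold higher number from compound 2 to compound 3 (0.51 log units; beyond the scatter), a weakening somewhat beyond the scatter rather than a move within it. For compound 3 the estimated value in this assay is therefore 450 nM, with a range from 120 nM to 2500 nM; a measured number is expected rather than a limit.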

Compound 3, half-maximal inhibitory concentration: 14900 nM
For compound 3 the middle estimate is 33-fold (1.52 log units) below the measured one; the measured number lies above the stated range.
By their numbers in this assay, from the lowest: compound 2; then compounds 3 and 1 (each within the scatter of the next).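

In this assay, going by these compounds alone, putting (pyrrolidin-1-yl)carbonyl in place of (pyrrolidin-1-yl)methyl gives a 110-fold higher number from compound 2 to compound 3 (2.03 log units; beyond the scatter), the first direct reading of a single change on the shared core, and a large one. This position, on a double-bonded ring carbon, therefore responds strongly to this change even though the pyrrolidine ring stays, and the hydrogen-bond donor count, acceptor count and net charge computed for the two groups are the same and do not separate them. Nothing available here bears on what lies behind the step.

Going by these compounds, it remains open whether other amines joined through the same single carbon, such as piperidin-1-ylmethyl or dimethylaminomethyl, keep the number of compound 2, and whether a different amide on the carbonyl, such as a dimethylamide or a piperidine amide, changes the number of compound 3. Also open, on these data alone, is how the hydroxymethyl group on this carbon compares with the (pyrrolidin-1-yl)methyl group on an otherwise unchanged core, since compound 1 differs from compound 2 in more than one place.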